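From Propoxycarbonyl to Carboxymethyl in Compound 3

The source may report more compounds than this note shows. Statements on the series, on what has been measured and on what is new or still open speak of the compounds shown alone.

In an ADME assay on a cell-free system (plasma, Homo sapiens) for metabolic stability, read by LC-MS (on this read-out lower numbers stand for a shorter-lived compound and higher numbers for a longer-lived compound), compound 2 `CCCOC(=O)c1ccc(NC(=O)c2cccc(-c3cc(C(=O)Nc4ccncc4F)ccc3CN)c2)cc1` gives > 2 h, which is a limit and not a number. Compound 1 `NCc1ccc(C(=O)Nc2ccncc2F)cc1-c1cccc(C(=O)Nc2cccc(CC(=O)O)c2)c1`, which also carries carboxymethyl, gives > 2 h, again a limit. Compound 3 `NCc1ccc(C(=O)Nc2ccncc2F)cc1-c1cccc(C(=O)Nc2ccc(CC(=O)O)cc2)c1` has carboxymethyl in place of propoxycarbonyl on an aromatic carbon, para to a large group (carboxymethyl in place of propoxycarbonyl on an aromatic carbon). Going by the values given here, the one measured step bearing on this is a step that the two limits leave unreadable from compound 1 to compound 2, and the evidence amounts to the limit of > 2 h in this assay, at which 2 of the 2 values shown sit. No step beyond the scatter is therefore expected in this assay, and the estimate is a step that the limit leaves unreadable from compound 2 to compound 3. Compound 3 is expected near 2.5 h, within 1.5 h to 5 h.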

Compound 3, half-life: > 2 h
Compound 3 was reported as a limit (the forecaster's own chance of this, stated with the estimate: 85%); the middle value is on the limit's open side.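

Going by these compounds alone, compound 1, compound 2 and compound 3 are all reported only as limits, so no step among them can be read. From the compounds shown here alone, how long each actually lasts in this assay, and whether the carboxymethyl change matters, stays open.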